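The source may hold more compounds than are shown below. What is called first, only, known or untested is meant among the compounds shown, and "the series" means these compounds.

Compound 1 `CCOc1ccc2oc(/C=C/[S+](C)[O-])cc(=O)c2c1` gives 1500 nM
Compound 2 `COc1ccc2c(=O)cc(/C=C/[S+](C)[O-])oc2c1` gives 2200 nM

Both numbers come from a functional assay on A549 cells (Homo sapiens) for cytotoxicity, with a stated time of 48 h (on this read-out higher numbers stand for weaker inhibition and lower numbers for stronger inhibition), and compound 1 stands within the usual scatter of compound 2. Compound 3 `CCCCOc1ccc2oc(/C=C/[S+](C)[O-])cc(=O)c2c1` has not yet been measured. It turns the ethoxy of compound 1 into butoxy, with ethyl in place of hydrogen on a saturated chain carbon, two bonds along the chain from an oxygen on an aromatic ring. For the measured compounds named here, no two measured compounds differ in one place only, so the data show no step for this change. In this assay no shift beyond the scatter is expected. The estimated change is a 1.1-fold higher number from compound 1 to compound 3 (0.05 log units; within the scatter). For compound 3 the expected value is 1700 nM, within an estimated range of 600 nM to 4500 nM.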

Compound 3, half-maximal inhibitory concentration: 1400 nM
Compound 3: middle estimate off by 1.2-fold (0.08 log units), on the high side, within the range that was stated.
By their numbers in this assay, from the lowest: compounds 3, 1 and 2 (each within the scatter of the next).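

In this assay, for the compounds shown here, the change from ethoxy to butoxy gives a 1.1-fold lower number from compound 1 to compound 3 (0.03 log units; within the scatter) and so provides the first single-place step. At this position on the shared core, ethyl in place of hydrogen on a saturated chain carbon therefore brings no shift beyond the scatter. No measurement given here accounts for this result. Still open, on these data alone, is whether a chain longer than butyl, a branched chain such as isopropyl, or a chain ending in an amine or a carboxylic acid would also leave the number within the scatter.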